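A few compounds are considered here, and "the series" means these few. Any claim that something is new, unique, unknown or untested is made for them only; others in the source may bear on it.

Values from a functional assay on DU-145 cells (Homo sapiens) for cytotoxicity, read by ELISA, with a stated time of 4 days (on this read-out higher numbers stand for weaker inhibition and lower numbers for stronger inhibition), for the two compounds measured so far:

- compound 1 `Clc1ccc(-c2cc(-c3ccoc3)cc(-c3ccco3)n2)s1` gives 17200 nM
- compound 2 `Clc1ccc(-c2cc(-c3ccco3)nc(-c3ccc(Cl)s3)c2)o1` gives 27700 nM

Compound 2 has the higher of the two numbers, but the gap lies within the scatter, so the pair cannot be separated. Compound 3 `Clc1cccc(-c2cc(-c3ccc(Cl)o3)cc(-c3ccc(Cl)s3)n2)c1` carries 3-chlorophenyl in place of furan-2-yl on an aromatic carbon, next to the ring nitrogen (3-chlorophenyl in place of furan-2-yl on an aromatic carbon). Among the measured compounds shown here, the only measured step (a 1.6-fold higher number from compound 1 to compound 2 (0.21 log units; within the scatter)) exchanged a different group, so it is a weak guide and shows only a small change. The expected step (a 1.7-fold lower number from compound 2 to compound 3 (0.24 log units; within the scatter)) stays within the scatter. For compound 3 the estimated value is 16000 nM, with an expected range of 5000 nM to 50000 nM.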

Compound 3, half-maximal inhibitory concentration: 21600 nM
Estimate against measurement, compound 3: 1.4-fold (0.13 log units) below; low and high end bracket the measured number.
By their numbers in this assay, from the lowest: compounds 1, 3 and 2 (each within the scatter of the next).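

On the aromatic carbon next to the ring nitrogen, putting 3-chlorophenyl in place of furan-2-yl gives a 1.3-fold lower number from compound 2 to compound 3 (0.11 log units; within the scatter) in this assay. This position therefore accepts a six-membered ring of carbon only, with 7 heavy atoms against 5 and no ring oxygen, without a separable shift in the number. No measured evidence here accounts for this result. Still open, as far as these compounds go, is whether a group of another kind at this position, such as an amine or a carboxylic acid, would give a number clear of the scatter.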